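Replacing Phenoxy with Phenethyl on a Shared Core

The compounds below may be only part of what the source reports. "The series", "measured", "known", "first", "only" and "open" are said of these compounds alone.

Of the compounds shown here, three built on one shared core have been measured in a functional assay on L1210 cells (Mus musculus), with a stated time of 12 days; on this read-out higher numbers stand for higher potency (the scale is a negative logarithm) and lower numbers for lower potency. Compound 1 `CCCC1=C(N2CC2)C(=O)C(CCC)=C(N2CC2)C1=O` gives 4.92, compound 2 `CC1=C(N2CC2)C(=O)C(COc2ccccc2)=C(N2CC2)C1=O` gives 5.15, and compound 3 `CCOC(COC(N)=O)C1=C(N2CC2)C(=O)C(C)=C(N2CC2)C1=O` gives 6.18. Compound 2 stands between the other two: its number and that of compound 1 lie within the usual scatter of each other, so no order can be read from them, while compound 3 lies beyond the scatter above compound 2. Among the compounds with values here, no pair of measured compounds differs in a single place, so the change below has to be judged from the structures alone.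

Compound 4 `CC1=C(N2CC2)C(=O)C(CCCc2ccccc2)=C(N2CC2)C1=O` differs from compound 2 in one place: phenethyl in place of phenoxy on a saturated chain carbon bound to a double-bonded ring carbon. The single hydrogen-bond acceptor of the phenoxy leaves, a phenethyl with none enters, and an aromatic ring remains on the chain. Within the data shown here, nothing among the measured compounds shows what such an exchange does, so in this assay the expected step is a number 0.05 log units lower from compound 2 to compound 4 (within the scatter), nothing beyond the scatter. Compound 4 is therefore estimated at 5.1 in this assay, with a range from 4.5 to 5.7.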

Compound 4, logarithm of the reciprocal of the active concentration, log(1/C): 4.47
For compound 4 the middle estimate is 0.63 log units above the measured one, and the stated range ends above it.
By their numbers in this assay, from the lowest: compound 4; then compounds 1 and 2 (each within the scatter of the next); then compound 3.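

Within the data shown here, this is the first step between two measured compounds that differ in one place, and it shows that the group on this saturated chain carbon bound to a double-bonded ring carbon matters in this assay: phenethyl in place of phenoxy gives a number 0.68 log units lower from compound 2 to compound 4 (beyond the scatter). Both groups carry an aromatic ring, so keeping that ring on the chain is not enough to hold the number. The two groups also differ in heavy atoms and hydrogen-bond acceptors, but no accompanying measurement shows which difference, if either, accounts for the step.

Going by these compounds, whether an amine or a carboxylic acid in this place would raise or lower the number remains open. A single pair also cannot show whether the same exchange would give a similar step on a different core.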